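Working notes: branched pentyl swap on the shared core

A few compounds are considered here, and "the series" means these few. Any claim that something is new, unique, unknown or untested is made for them only; others in the source may bear on it.

In an assay for binding affinity to Corticotropin releasing factor receptor (Rattus norvegicus) (a lower number here means a stronger inhibitor, a higher number a weaker inhibitor), compound 1 `CCc1nc2c(-c3ccc(C(F)(F)F)cc3Cl)nccc2n1C(CC)CC` gives 5.4 nM; compound 2 `CCCC(C)n1c(CC)nc2c(-c3ccc(OC(F)F)cc3C)nccc21` gives 9 nM and compound 3 `CCCC(C)n1c(CC)nc2c(-c3ccc(Cl)cc3C)nccc21` gives 9.1 nM, both differing from compound 1 only within the scatter. Among the compounds with values here, the one measured step, a 1.0-fold higher number from compound 2 to compound 3 (0.00 log units; within the scatter), is likewise within the scatter. Compound 4 `CCCC(C)n1c(CC)nc2c(-c3ccc(C(F)(F)F)cc3Cl)nccc21` is drawn from compound 1 by 1-methylbutyl in place of pentan-3-yl on an aromatic nitrogen. Within the data shown here, no measured step exchanges these two branched chains; compounds 2 and 3, which carry 1-methylbutyl, only show that this group sits on a core whose numbers lie close to that of compound 1. The change is therefore expected to be small, a 1.3-fold higher number from compound 1 to compound 4 (0.11 log units; within the scatter), probably none beyond the scatter. Compound 4 is estimated at 7 nM, with a range from 3 nM to 16 nM.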

Compound 4, inhibition constant: 3.5 nM
Compound 4: the middle estimate sits 2.0-fold (0.30 log units) above what was measured; the range from low to high includes it.
By their numbers in this assay, from the lowest: compounds 4, 1, 2 and 3 (each within the scatter of the next, the first and the last beyond it).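

At the aromatic nitrogen of the shared core, the exchange of pentan-3-yl for 1-methylbutyl can now be read directly: in this assay the step is a 1.5-fold lower number from compound 1 to compound 4 (0.19 log units; within the scatter) and so shows no change beyond the scatter. Within the data shown here, with this aryl group, the two branched chains are interchangeable within that scatter, which the earlier compounds could only suggest. Nothing available explains this result.
From the compounds shown here alone, whether a straight pentyl chain, a cyclopentyl ring or a shorter isopropyl group stays in the same range remains open. So does whether this exchange reads the same with the aryl groups of compound 2 and compound 3.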